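Notes on compound 4 against three measured analogues

This account rests on a few compounds, and the source may have more. Where it says the series, first, only, none or still open, it means among the compounds named here.

Measured so far:
compound 1, `COc1ccc(CCCCCCCCOc2ccc(COc3cccc(C(=O)O)c3)[n+]([O-])c2/C=C/C(=O)O)cc1`: 150 nM
compound 2, `COc1ccc(CCCCCCCCOc2ccc(CSc3cccc(NS(=O)(=O)C(F)(F)F)c3)nc2/C=C/C(=O)O)cc1`: 284 nM
compound 3, `COc1ccc(CCCCCCCCOc2ccc(CSc3cccc(N)c3)nc2/C=C/C(=O)O)cc1`: 34 nM

All three numbers come from an assay for binding affinity to leukotriene B4 receptor 1 (Homo sapiens); a lower number here means a stronger inhibitor, a higher number a weaker inhibitor. Compound 3 holds the lowest number of the three; compound 1 sits above it with a gap beyond the scatter, and compound 2 sits higher still. The one step that joins two of these compounds by a single change is an 8.4-fold lower number from compound 2 to compound 3 (0.92 log units; beyond the scatter); it shows that the nitrogen on the aromatic ring of the thioether side is a place where a change registers clearly in this assay.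

Compound 4, `COc1ccc(CCCCCCCCOc2ccc(C[S+]([O-])c3cccc(N(C)C)c3)nc2/C=C/C(=O)O)cc1`, differs from compound 3 by a group of 11 heavy atoms (8 carbon, 1 nitrogen, 1 oxygen, 1 sulfur; one six-membered aromatic ring of carbon only) in place of a group of 8 heavy atoms (6 carbon, 1 nitrogen, 1 sulfur; one six-membered aromatic ring of carbon only), on a saturated chain carbon bound to an aromatic carbon. For the measured compounds named here, the change touches the same nitrogen as the step from compound 2 to compound 3, but it also alters the sulfur, and no measured pair isolates either part. With the hydrogen-bond donor count falling to none, and the step from compound 2 to compound 3 having moved the number downward when a substituent was taken off that nitrogen, a move in the opposite direction, of modest size, is expected, with wide uncertainty. Compound 4 is therefore estimated at 90 nM, within 25 nM to 320 nM, which means an expected step of a 2.6-fold higher number from compound 3 to compound 4 (0.42 log units; beyond the scatter).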

Compound 4, inhibition constant: 245 nM
The estimate for compound 4 lay 2.7-fold (0.43 log units) below the measured number; the measured number falls inside the stated range.
By their numbers in this assay, from the lowest: compound 3; then compounds 1, 4 and 2 (each within the scatter of the next).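

In this assay, the replacement gives a 7.2-fold higher number from compound 3 to compound 4 (0.86 log units; beyond the scatter), so the (3-aminophenyl)sulfanyl group on a saturated chain carbon bound to an aromatic carbon is a place where this larger group, with no hydrogen-bond donors, registers clearly. Read with an 8.4-fold lower number from compound 2 to compound 3 (0.92 log units; beyond the scatter), the series now has two compounds, compound 2 and compound 4, that change the group of compound 3 and carry a higher number, and none among these compounds that changes this group and carries a lower one; this holds only for these three compounds. No accompanying measurement speaks to the reason for the rise from compound 3 to compound 4.

The compounds shown leave open how that rise divides between the oxygen added on the sulfur and the two methyl groups added on the nitrogen, since neither change stands alone here. Also open, from the compounds shown here alone, is whether a smaller nitrogen substituent, such as a single methyl or an acetyl group, would keep the number near that of compound 3, which gives 34 nM.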